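From Hexyloxy to Bromo: A Small Step Expected

The source may report more compounds than this note shows. Statements on the series, on what has been measured and on what is new or still open speak of the compounds shown alone.

In a functional assay on A549 cells (Homo sapiens) for antiproliferative activity, read by MTT assay, with a stated time of 48 h (on this read-out lower numbers stand for stronger inhibition and higher numbers for weaker inhibition), compound 1 `COc1ccc(/C=C/c2cc(OC)cc(OC)c2/C=C/C(=O)c2cccc(OC)c2)cc1` gives 6.1 ug/mL and compound 2 `CCCCCCOc1ccc(C(=O)/C=C/c2c(/C=C/c3ccc(OC)cc3)cc(OC)cc2OC)cc1` gives 8.4 ug/mL and these two numbers lie within the usual scatter of each other, so compound 2 stands level with compound 1. The next structure is compound 3 `COc1ccc(/C=C/c2cc(OC)cc(OC)c2/C=C/C(=O)c2ccc(Br)cc2)cc1` which has not been measured yet. It differs from compound 2 in one place, bromo in place of hexyloxy on an aromatic carbon with bromo in place of hexyloxy on an aromatic carbon, para to a large group. Among the compounds with values here, no measured pair differs in one place only, so no direct step is available as a guide. The only hint is how close compound 1 at 6.1 ug/mL and compound 2 at 8.4 ug/mL sit, so no change beyond the scatter is expected in this assay for this swap. The estimated move is a 1.3-fold lower number from compound 2 to compound 3 (0.11 log units; within the scatter) and stays within the scatter. For compound 3 the expected value is 6.5 ug/mL within a range of 2.5 ug/mL to 16 ug/mL on this estimate.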

Compound 3, half-maximal inhibitory concentration: 8.3 ug/mL
The estimate for compound 3 lay 1.3-fold (0.11 log units) below the measured number; the measured number falls inside the stated range.
By their numbers in this assay, from the lowest: compounds 1, 3 and 2 (each within the scatter of the next).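

In this assay, the long hexyloxy chain and the single bromo atom on this aromatic carbon give a 1.0-fold lower number from compound 2 to compound 3 (0.01 log units; within the scatter), so this position shows no measurable preference between these two groups, even though hexyloxy counts one hydrogen-bond acceptor and bromo none. Changing the group on the carbonyl carbon, with 4-bromophenyl in place of 3-methoxyphenyl, gives a 1.4-fold higher number from compound 1 to compound 3 (0.13 log units; within the scatter), which also stays within the usual scatter. Nothing available here explains why these numbers stay level.

The compounds shown leave open whether this level would hold with an amine or a carboxylic acid on the same aromatic carbon. They also leave open whether a chain longer than hexyloxy would still read the same, or whether it would finally move the number beyond the scatter.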